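Alkenyl amide series: bromo for tert-butyl on the aryl ring

A few compounds are considered here, and "the series" means these few. Any claim that something is new, unique, unknown or untested is made for them only; others in the source may bear on it.

Working notes on a set of quinoline-core amides tested in an assay on isolated protein for displacement of a labelled ligand from melanin-concentrating hormone receptor 1 (Homo sapiens); a lower number here means a stronger inhibitor, a higher number a weaker inhibitor. Compound 1 `CCCc1cc(N)c2cc(NC(=O)CCc3ccccc3)ccc2n1` gives 8300 nM. Compound 2 `CC(C)(C)c1cc(N)c2cc(NC(=O)/C=C/c3ccc(C(F)(F)F)cc3)ccc2n1` gives 0.3 nM. Compound 3 `CCCc1cc(N)c2cc(NC(=O)/C=C/c3ccc(C(C)(C)C)cc3)ccc2n1` gives 22 nM. Among these three numbers compound 3 stands second highest: its number lies below that of compound 1 by a wide gap and above that of compound 2 by a wide gap, both gaps beyond the scatter. Going by the values given here, no two measured compounds differ in one place only, so no single step can be read from the measured set.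

Compound 4 `CCCc1cc(N)c2cc(NC(=O)/C=C/c3ccc(Br)cc3)ccc2n1` is yet to be measured. It differs from compound 3 by bromo in place of tert-butyl on an aromatic carbon. Among the compounds with values here, with no measured pair isolating this exchange, the size of the step is open; the expectation is a small change, a 1.5-fold lower number from compound 3 to compound 4 (0.17 log units; within the scatter), not clearly beyond the scatter in either direction. The estimate for compound 4 in this assay is 15 nM, with a range from 3 nM to 80 nM.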

Compound 4, half-maximal inhibitory concentration: 4 nM
Estimate against measurement, compound 4: 3.8-fold (0.57 log units) above, and the stated range covers the measured number.
By their numbers in this assay, from the lowest: compound 2; then compound 4; then compound 3; then compound 1.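

The exchange of bromo for tert-butyl on an aromatic carbon gives the series its first step that can be read at a single place: in this assay the step is a 5.5-fold lower number from compound 3 to compound 4 (0.74 log units; beyond the scatter). At this position, para to a large group, the four-carbon tert-butyl is therefore not needed for binding, and a single bromine gives the lower number with the rest of the structure unchanged. No measurement shown here bears on what lies behind this step.

Steps to the other compounds cannot be read, since each differs from the pair in more than one place, so the effect of trifluoromethyl at this position remains separate and unresolved. Also open, as far as these compounds go, is how a chloro, methoxy or nitrile group at the same position would compare with bromo.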